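The source may report more compounds than this note shows. Statements on the series, on what has been measured and on what is new or still open speak of the compounds shown alone.

Measured so far:
compound 1 `COc1cc2ncnc(Nc3ccc(F)c(Cl)c3)c2cc1NC(=O)/C=C/c1ccc(F)cc1Cl` gives "not determined" (no result reported)
compound 2 `COc1cc(/C=C/C(=O)Nc2cc3c(Nc4ccc(F)c(Cl)c4)ncnc3cc2O[C@H]2CCOC2)cc(OC)c1OC` gives 24500 nM
compound 3 `COc1cc(/C=C/C(=O)Nc2cc3c(Nc4ccc(F)c(Cl)c4)ncnc3cc2OC)cc(OC)c1` gives "not determined" (no result reported)

For the measured compounds named here, in a functional assay on HeLa cells (Homo sapiens) for cytotoxicity, read by MTT assay, with a stated time of 72 h (on this read-out lower numbers stand for stronger inhibition and higher numbers for weaker inhibition), compound 2 gives 24500 nM and this is the only number available. Compound 1 and compound 3 have no result, so compound 2 cannot be ranked against any neighbour.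

The next compound to be tested is compound 4 (`O=C(/C=C/c1ccccc1[N+](=O)[O-])Nc1cc2c(Nc3ccc(F)c(Cl)c3)ncnc2cc1O[C@H]1CCOC1`), which differs from compound 2 in one group (2-nitrophenyl in place of 3,4,5-trimethoxyphenyl on a double-bonded chain carbon bound to a double-bonded chain carbon). In words, this is 2-nitrophenyl in place of 3,4,5-trimethoxyphenyl on a double-bonded chain carbon bound to a double-bonded chain carbon.

Going by the values given here, no two measured compounds differ in only one place, so the data offer no earlier step as a guide to this swap. In this assay, among the compounds with values here, the expectation is therefore no step clearly beyond the usual scatter of repeated measurements, with a slight lean toward stronger inhibition. The estimated change is a 1.5-fold lower number from compound 2 to compound 4 (0.19 log units; within the scatter) on this read-out. This expectation rests on compound 2 at 24500 nM alone, so the range has to stay wide. The estimated value for compound 4 is 16000 nM with 5000 nM to 50000 nM as its expected range.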

Compound 4, half-maximal inhibitory concentration: 29600 nM
Compound 4: middle estimate off by 1.9-fold (0.27 log units), on the low side, and the stated range covers the measured number.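

For the compounds shown here, replacing 3,4,5-trimethoxyphenyl with 2-nitrophenyl on a double-bonded chain carbon bound to a double-bonded chain carbon gives a 1.2-fold higher number from compound 2 to compound 4 (0.08 log units; within the scatter) in this assay and provides the first readable step at this position. The two groups share one six-membered aromatic ring of carbon only but otherwise differ considerably, with a nitro group taking the place of three methoxy groups, yet this swap does not separate compound 2 from compound 4 in this assay. Nothing measured here explains this outcome, and a single step cannot show how the position responds to other groups.

From the compounds shown here alone, whether a phenyl ring carrying a carboxylic acid or an amine, or a cyclohexyl group in place of the aromatic ring, would produce a step beyond the usual scatter remains open. Compound 1 and compound 3 have no result, so they cannot show whether the same swap would behave alike with the methoxy group they carry on the shared core.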